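A few compounds are considered here, and "the series" means these few. Any claim that something is new, unique, unknown or untested is made for them only; others in the source may bear on it.

Of the compounds shown here, two have so far been tested in a functional assay on MOLT-4 cells (Homo sapiens) for inhibition, read by sulforhodamine B assay, with a stated time of 48 h; a lower number here means a stronger inhibitor of growth, a higher number a weaker inhibitor of growth. Compound 1, `COc1ccc(-c2cc(/C=C/C(=O)c3ccc(N)cc3)[nH]n2)cc1`, gives 2320 nM. Compound 2, `COc1cc(-c2cc(/C=C/C(=O)c3ccc(Cl)c(Cl)c3)[nH]n2)cc(OC)c1OC`, gives 4380 nM. Among the measured compounds shown here, as the numbers stand, the one for compound 2 is the larger of the two, yet its nearest neighbour is compound 1 and the gap between them falls within the usual scatter of repeated measurements, so no real difference between the two can be claimed. Compound 1 and compound 2 also differ in more than one place, so no single structural change can be followed between them.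

Compound 3, `COc1cc(-c2cc(/C=C/C(=O)c3ccc(F)c(F)c3)[nH]n2)cc(OC)c1OC`, has not yet been measured in this assay. It differs from compound 2 in one place only: 3,4-difluorophenyl in place of 3,4-dichlorophenyl on a carbonyl carbon. The carbonyl carbon that carries this ring has a double-bonded chain carbon as its other neighbour, and everything else in the molecule stays the same.

For the measured compounds named here, with no comparable step among the measured compounds to lean on, the step expected here is a 1.3-fold higher number from compound 2 to compound 3 (0.10 log units; within the scatter), a shift no larger than the scatter, leaning slightly toward a weaker inhibitor of growth. Compound 3 is therefore expected to give 5500 nM in this assay, with a range from 2200 nM to 14000 nM.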

Compound 3, concentration for 50% growth inhibition: 2720 nM
For compound 3 the middle estimate is 2.0-fold (0.31 log units) above the measured one; low and high end bracket the measured number.
By their numbers in this assay, from the lowest: compounds 1, 3 and 2 (each within the scatter of the next).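

Among the compounds shown here, this is the first step that can be followed at a single place: in this assay, 3,4-difluorophenyl in place of 3,4-dichlorophenyl on the carbonyl carbon gives a 1.6-fold lower number from compound 2 to compound 3 (0.21 log units; within the scatter). The two halogen pairs therefore cannot be told apart in this read-out, and with the rest of the molecule held fixed, this exchange of chlorine for fluorine shows no real effect on growth inhibition. Nothing measured here offers an explanation for this result.

The compounds shown leave open whether this position responds to any change at all, since both rings carry two halogens; a plain phenyl ring, or one bearing a carboxylic acid, would test that far more strictly than a swap of one halogen for another. On these data alone, it also remains open whether the same exchange would read the same way on a different ring at the other end of the molecule, and compound 1 cannot settle this, as it differs from the other two compounds in more than one place.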